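This account rests on a few compounds, and the source may have more. Where it says the series, first, only, none or still open, it means among the compounds named here.

The measured compounds and their values:

compound 1, `Cc1nc(N)c2c(-c3ccccc3)cn([C@@H]3O[C@H](CO)[C@@H](O)[C@H]3O)c2n1`, gives > 20000 nM in a functional assay on HepG2 cells (Homo sapiens) for antiproliferative activity, read by XTT assay, with a stated time of 72 h; on this read-out higher numbers stand for weaker inhibition and lower numbers for stronger inhibition
compound 2, `C#Cc1cn([C@@H]2O[C@H](CO)[C@@H](O)[C@H]2O)c2nc(C)nc(N)c12`, gives > 20000 nM in this assay
compound 3, `COc1ncnc2c1c(-c1ccccc1)cn2[C@@H]1O[C@H](CO)[C@@H](O)[C@H]1O`, gives > 20000 nM in this assay

For compound 1 this value is a limit of the assay, not a measured number. The same holds for compound 2. The same holds for compound 3. All three share a nucleoside-like build, a sugar attached to a two-ring core, and differ only in what sits on that core.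

Compound 2 differs from compound 1 by ethynyl in place of phenyl on an aromatic carbon. In this assay this gives a step that the two limits leave unreadable from compound 1 to compound 2; its size cannot be read because the limit of > 20000 nM in this assay, at which 3 of the 3 values shown sit, leaves open how far either compound really lies from the edge of the assay.

Compound 3 and compound 1 carry different cores; the difference between the two cores is not broken down here.

Compound 4, `C#Cc1cn([C@@H]2O[C@H](CO)[C@@H](O)[C@H]2O)c2ncnc(OC)c12`, has not yet been measured. Among the measured compounds shown here, it differs from compound 3 by ethynyl in place of phenyl on an aromatic carbon, which is the same change, at the same place, as the one that turns compound 1 into compound 2.

The step in this assay is expected to be a step that the limit leaves unreadable from compound 3 to compound 4, an expectation that rests on a step that the two limits leave unreadable from compound 1 to compound 2 being unreadable and on (the limit of > 20000 nM in this assay, at which 3 of the 3 values shown sit). Compound 4 is therefore estimated at 40000 nM, between 15000 nM and 150000 nM, and the assay is expected most likely to report only a limit again.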

Compound 4, half-maximal inhibitory concentration: 12700 nM
Compound 4: the middle estimate sits 3.1-fold (0.50 log units) above what was measured; measured number below the stated range.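

In this assay, putting ethynyl in place of phenyl gives an at least 1.5-fold lower number from compound 3 to compound 4 (0.19 log units; that floor lies within the scatter), and compound 4, at 12700 nM, is the only compound shown that has a measured number rather than a limit. Going by these compounds, the other end of that step is a limit: the size printed is only a floor, that floor lies within the usual scatter, and how large the step really is stays unknown. Nor does this show that the change acts alike on both cores, because the matching step on the core of compound 1 cannot be read, with both of its ends at a limit: the limit of > 20000 nM in this assay, at which 3 of the 4 values shown sit.

The compounds shown leave open how other groups on the same aromatic carbon would read in this assay, for instance an amine, a carboxylic acid or a longer carbon chain in place of ethynyl. They also leave open whether the change would give a readable step on any core beyond these two, so one measured value is no basis for a rule across the series.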